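Bromo in place of chloro on the shared core

The source may hold more compounds than are shown below. What is called first, only, known or untested is meant among the compounds shown, and "the series" means these compounds.

In an ADME assay on HEK293 cells (Homo sapiens) for cytotoxicity (a higher number here means that more compound is needed for the effect, a lower number that less compound is needed), compound 3 `Clc1ccc(C2CNCCNCCNCCN2)cc1` stands highest of two numbers at 181000 nM while compound 2 `FC(F)(F)c1ccc(C2CNCCNCCNCCN2)cc1` gives 73000 nM in the same test. Compound 1 `CC(C)(C)C1CNCCNCCNCCN1` gives > 200000 nM as a limit of the assay and not a number. Compound 4 `Brc1ccc(C2CNCCNCCNCCN2)cc1` has bromo in place of chloro on an aromatic carbon, para to a large group (bromo in place of chloro on an aromatic carbon). Within the data shown here, the one measured step at this place, with chloro in place of trifluoromethyl, is modest (a 2.5-fold higher number from compound 2 to compound 3 (0.39 log units; beyond the scatter)). Among the measured compounds shown here, no step from chloro to bromo has been measured, so no step beyond the scatter is expected in this assay for this change (a 1.3-fold lower number from compound 3 to compound 4 (0.11 log units; within the scatter)). Compound 4 is estimated at 140000 nM within an expected range of 80000 nM to 210000 nM overall.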

Compound 4, half-maximal effective concentration in the HEK293 assay: > 200000 nM
Compound 4: a limit, no number; the forecaster's own chance of this, stated with the estimate: 20%; at least 1.4-fold (0.15 log units) between middle value and limit.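

In the HEK293 assay compound 4 gives > 200000 nM as a limit of the assay and not a number, so the size of the change from chloro to bromo stays unfixed because the read-out stops there: the limit of > 200000 nM in the HEK293 assay, at which 2 of the 4 values shown sit.

In the HEK293 assay the floor is an at least 1.1-fold higher number from compound 3 to compound 4 (0.04 log units; that floor lies within the scatter), while bromo in place of trifluoromethyl gives an at least 2.7-fold higher number from compound 2 to compound 4 (0.43 log units; beyond the scatter), so at this place trifluoromethyl stands apart from both halogens. In a physicochemical assay for lipophilicity (a lower number here means a more polar compound, a higher number a more lipophilic compound), compound 3 gives 0.8 and compound 4 gives 0.7 in the same test. In the physicochemical assay the same change from chloro to bromo gives a number 0.10 log units lower from compound 3 to compound 4 (within the scatter).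

Open, as far as these compounds go, is how fluoro, an amine or a carboxylic acid at this place would read in the HEK293 assay.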